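Methoxy in place of hydrogen on the aromatic ring of compound 1

The source may hold more compounds than are shown below. What is called first, only, known or untested is meant among the compounds shown, and "the series" means these compounds.

Compound 1 `c1ccc(Cc2nnc(Cn3nnc4ccccc43)o2)cc1` stands at the ceiling of an ADME assay on cells (Macrophage, Homo sapiens) for inhibition; on this read-out higher numbers stand for lower toxicity in this test and lower numbers for higher toxicity in this test: in this assay compound 1 gives > 100000 nM, a limit rather than a number. Compound 2 `Brc1cccc(Cc2nnc(Cn3nnc4ccccc43)o2)c1` in this assay gives > 100000 nM, again a limit. Compound 3 `COc1cccc(Cc2nnc(Cn3nnc4ccccc43)o2)c1` in this assay gives > 100000 nM, also a limit. Because of the limit of > 100000 nM in this assay, at which 3 of the 3 values shown sit, the steps a step that the two limits leave unreadable from compound 1 to compound 2, a step that the two limits leave unreadable from compound 1 to compound 3 and a step that the two limits leave unreadable from compound 2 to compound 3 cannot be sized. Compound 4 `COc1ccc(Cc2nnc(Cn3nnc4ccccc43)o2)cc1` differs from compound 1 by methoxy in place of hydrogen on an aromatic carbon. The step that the two limits leave unreadable from compound 1 to compound 3 bears most closely on this change, yet its size is unreadable. Compound 4 is therefore expected to remain at the limit, an expected step of a number no higher from compound 1 to compound 4 (the limit leaves the size open) of nothing beyond the scatter. Compound 4 is estimated at 100000 nM, between 40000 nM and 250000 nM.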

Compound 4, half-maximal cytotoxic concentration: > 100000 nM
Compound 4 gave a limit, no number; the forecaster's own chance of this, stated with the estimate: 85%; the middle value lies on the limit itself.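

Going by these compounds alone, no step from compound 1, compound 2 or compound 3 to compound 4 can be read in this assay, because all four compounds stand at the same limit: the limit of > 100000 nM in this assay, at which 4 of the 4 values shown sit. The compounds shown leave open whether bromo or methoxy changes the half-maximal cytotoxic concentration at all.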